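Oxane in place of hydroxycyclohexyl on the methylene-linked amine

The source may report more compounds than this note shows. Statements on the series, on what has been measured and on what is new or still open speak of the compounds shown alone.

Of the compounds shown here, three sharing one core have been measured in an assay on isolated protein for inhibition of protein kinase C delta type (Homo sapiens), read by TR-FRET, with a stated time of 2 h; on this read-out lower numbers stand for stronger inhibition and higher numbers for weaker inhibition. Compound 1 `N#Cc1cnc(NCc2cnccc2C(F)(F)F)cc1N[C@H]1C[C@@H](O)C1` carries a 3-hydroxycyclobutyl group on the aromatic nitrogen; in this assay compound 1 gives only a limit, > 10000 nM. Compound 2 `N#Cc1cnc(NCc2cnccc2C(F)(F)F)cc1N[C@H]1CC[C@H](O)CC1` bears 4-hydroxycyclohexyl there, and in this assay compound 2 gives 6500 nM. Compound 3 `N#Cc1cnc(NCc2cnccc2C(F)(F)F)cc1NC[C@H]1CC[C@H](O)CC1`, with (4-hydroxycyclohexyl)methyl on that nitrogen, gives 2000 nM in this assay, the lowest of the two numbers shown; the step of a 3.3-fold lower number from compound 2 to compound 3 (0.51 log units; beyond the scatter) is beyond the scatter, and so is an at least 5.0-fold lower number from compound 1 to compound 3 (0.69 log units; beyond the scatter), while an at least 1.5-fold lower number from compound 1 to compound 2 (0.18 log units; that floor lies within the scatter) rests on a limit of > 10000 nM in this assay, at which 1 of the 3 values shown sits, and stays within the scatter.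

Compound 4 `N#Cc1cnc(NCc2cnccc2C(F)(F)F)cc1NCC1CCOCC1` is the next step from compound 3: oxan-4-yl in place of 4-hydroxycyclohexyl on a saturated chain carbon bound to a nitrogen on an aromatic ring. For the measured compounds named here, none of the measured steps alters this part of the molecule; they change ring size and the methylene linker, both of which compound 4 keeps from compound 3. Going by the values given here, the account therefore has no measured step that directly bears on the exchange, and the expected change in this assay is modest and more likely towards a higher number than a lower one. The estimate for compound 4 in this assay is 3500 nM, within 1200 nM to 10000 nM, which would be a step of a 1.8-fold higher number from compound 3 to compound 4 (0.24 log units; within the scatter) expected from compound 3 to compound 4.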

Compound 4, half-maximal inhibitory concentration: 5000 nM
Estimate against measurement, compound 4: 1.4-fold (0.15 log units) below; the measured number falls inside the stated range.
By their numbers in this assay, from the lowest: compound 3; then compounds 4 and 2 (each within the scatter of the next). At a limit, above all of these: compound 1.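

For the compounds shown here, putting oxan-4-yl in place of 4-hydroxycyclohexyl in this assay gives a 2.5-fold higher number from compound 3 to compound 4 (0.40 log units; beyond the scatter) and is the first measured change to this ring that keeps the methylene linker, showing that the ring itself still matters at this position. The exchange takes this group from 1 hydrogen-bond donor to 0, and the advantage of a 3.3-fold lower number from compound 2 to compound 3 (0.51 log units; beyond the scatter) does not carry over to the new ring, since a 1.3-fold lower number from compound 2 to compound 4 (0.11 log units; within the scatter) leaves those two compounds level. The remaining step, an at least 2.0-fold lower number from compound 1 to compound 4 (0.30 log units; that floor lies within the scatter), rests on a limit and not on a number, so it shows only a floor: the limit of > 10000 nM in this assay, at which 1 of the 4 values shown sits.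

The compounds shown cannot separate the loss of the hydroxyl from the placing of an oxygen in the ring, a question that a plain cyclohexylmethyl or a 4-methoxycyclohexylmethyl group on the same nitrogen would address. They also leave open how an amine in place of the hydroxyl, or a longer chain between the nitrogen and the ring, would read in this assay on this core.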